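Halogen position on the anilide of the shared core

The source may report more compounds than this note shows. Statements on the series, on what has been measured and on what is new or still open speak of the compounds shown alone.

The shared core carries an anilide whose halogen is varied. Compound 1 `COc1cc2c(cc1OC)C(=O)C(C(=O)Nc1ccc(F)cc1)C2` gives 55 ug/mL in a physicochemical assay, with a stated time of 30 min; a lower number here means a stronger inhibitor, a higher number a weaker inhibitor. Compound 2 `COc1cc2c(cc1OC)C(=O)C(C(=O)Nc1ccc(Cl)cc1)C2` gives 56.8 ug/mL in this assay, and compound 3 `COc1cc2c(cc1OC)C(=O)C(C(=O)Nc1cccc(Br)c1)C2` gives 58.9 ug/mL. Compound 2 stands close to both neighbours: a 1.0-fold higher number from compound 1 to compound 2 (0.01 log units; within the scatter), and a 1.0-fold higher number from compound 2 to compound 3 (0.02 log units; within the scatter). Compound 4 `COc1cc2c(cc1OC)C(=O)C(C(=O)Nc1ccccc1Br)C2` is not yet measured. From compound 2 it differs by 2-bromophenyl in place of 4-chlorophenyl on an amide-type nitrogen.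

For the measured compounds named here, two measured steps bear on this change. The move from a 4-chlorophenyl to a 3-bromophenyl on the amide-type nitrogen gave a 1.0-fold higher number from compound 2 to compound 3 (0.02 log units; within the scatter), and the related move from a 4-fluorophenyl gave a 1.1-fold higher number from compound 1 to compound 3 (0.03 log units; within the scatter). Neither moving the halogen around the ring nor exchanging one halogen for another has shifted the number beyond the scatter in this series, so no step beyond the scatter is expected for the 2-bromophenyl either. The expected step is a 1.0-fold higher number from compound 2 to compound 4 (0.00 log units; within the scatter). Compound 4 is therefore estimated at 57 ug/mL in this assay, with a range from 38 ug/mL to 85 ug/mL.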

Compound 4, half-maximal inhibitory concentration: 65.4 ug/mL
For compound 4 the middle estimate is 1.1-fold (0.06 log units) below the measured one; the range from low to high includes it.
By their numbers in this assay, from the lowest: compounds 1, 2, 3 and 4 (each within the scatter of the next).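

For the compounds shown here, compound 3 and compound 4 carry the same halogen, so this pair is the first to read the position of bromine on the anilide without a change of halogen, and that move stays within the scatter (a 1.1-fold higher number from compound 3 to compound 4 (0.05 log units; within the scatter)). The 2-bromophenyl on the amide-type nitrogen also stays within the scatter of the two other anilides (a 1.2-fold higher number from compound 2 to compound 4 (0.06 log units; within the scatter); a 1.2-fold higher number from compound 1 to compound 4 (0.08 log units; within the scatter)). In this assay, all three halogen positions printed for this series therefore give numbers that the scatter does not separate. No measurement at hand offers a reason for these numbers.

Going by these compounds, whether any group on this phenyl can move the number beyond the scatter remains open, since an amine, a carboxylic acid or a longer alkyl chain in place of the halogen would be a different kind of change. The compounds shown also say nothing about replacing the methoxy groups of the shared core.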